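Crown-ether esters: phenyl in place of phenoxy

The source may report more compounds than this note shows. Statements on the series, on what has been measured and on what is new or still open speak of the compounds shown alone.

Measured compounds in a functional assay on WiDr cells (Homo sapiens) for inhibition, read by sulforhodamine B assay, with a stated time of 48 h; a higher number here means a weaker inhibitor of growth, a lower number a stronger inhibitor of growth:
compound 1, `O=C(CCCCCc1ccccc1)OCC1COCCOCCOCCOCCOCCO1`, gives > 100000 nM, a limit of the assay.
compound 2, `CC(C)=CC1C(C(=O)OCC2COCCOCCOCCOCCOCCO2)C1(C)C`, gives 56000 nM.
compound 3, `O=C(CCCCOc1ccccc1)OCC1COCCOCCOCCOCCOCCO1`, gives > 100000 nM, again a limit of the assay.

Compound 3 thus stands only as a limit, one of two such values shown (the limit of > 100000 nM in this assay, at which 2 of the 3 values shown sit). Within the data shown here, compound 2 gives the single real number, and the step of an at least 1.7-fold higher number from compound 2 to compound 3 (0.25 log units; that floor lies within the scatter) is read against the limit. The step that the two limits leave unreadable from compound 1 to compound 3 is unreadable, both ends being limits.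

Compound 4, `O=C(CCCCc1ccccc1)OCC1COCCOCCOCCOCCOCCO1`, differs from compound 3 by phenyl in place of phenoxy on a saturated chain carbon, four bonds along the chain from a carbonyl carbon. This step bears the same chain length as compound 3 and is one methylene short of compound 1; since the step that the two limits leave unreadable from compound 1 to compound 3 cannot be read, no sign is fixed. Compound 4 is expected to remain at the limit as compound 1 does, so the expected step that the limit leaves unreadable from compound 3 to compound 4 is none readable; compound 4 is estimated at 150000 nM, within 60000 nM to 400000 nM.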

Compound 4, concentration for 50% growth inhibition: > 100000 nM
Compound 4: no number, only a limit; the forecaster's own chance of this, stated with the estimate: 80%; the middle value does not contradict the limit.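

In this assay, phenyl in place of phenoxy leaves compound 4 at a limit of the assay, and the steps from compound 3 and from compound 1 to compound 4 cannot be read. Against the 2,2-dimethyl-3-(2-methylprop-1-en-1-yl)cyclopropyl ester, the result is an at least 1.7-fold higher number from compound 2 to compound 4 (0.25 log units; that floor lies within the scatter). The phenyl and phenoxy chain esters compound 1, compound 3 and compound 4 all sit at the limit, and only compound 2 goes against this: the limit of > 100000 nM in this assay, at which 3 of the 4 values shown sit.

From the compounds shown here alone, how far compound 1, compound 3 and compound 4 lie beyond the limit stays open, so the effect of phenyl against phenoxy remains unknown. Also open, going by these compounds, is whether an amine or a carboxylic acid at the end of the chain would give a readable number.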